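Shortening the benzyl link in a thiadiazolo-fused aniline series

This account rests on a few compounds, and the source may have more. Where it says the series, first, only, none or still open, it means among the compounds named here.

Measured compounds:
Compound 1, `Nc1cccc(-c2cn3nc(-c4cccs4)sc3n2)c1`: > 250000 nM
Compound 2, `C=C(Br)C(=O)Nc1cccc(-c2cn3nc(Cc4ccccc4)sc3n2)c1`: 3000 nM
Compound 3, `Nc1cccc(-c2cn3nc(CCc4ccccc4)sc3n2)c1`: 31000 nM

In a functional assay on L1210 cells (Mus musculus) for inhibition, read by cell counting, with a stated time of 2 days (on this read-out lower numbers stand for stronger inhibition and higher numbers for weaker inhibition), compound 3 gives the higher of the two numbers shown; compound 2 gives a lower number, and that gap lies beyond the scatter. Compound 1 shows only a limit in this assay, (the limit of > 250000 nM in this assay, at which 1 of the 3 values shown sits), and no number. Compound 4, `Nc1cccc(-c2cn3nc(Cc4ccccc4)sc3n2)c1`, is not yet measured; it differs from compound 3 by phenyl in place of benzyl on a saturated chain carbon bound to an aromatic carbon, that is, a phenyl in place of a benzyl on a saturated chain carbon bound to an aromatic carbon. Within the data shown here, no measured pair shows this step directly, so in this assay the step from compound 3 to compound 4 is expected to be small, of size a 1.0-fold lower number from compound 3 to compound 4 (0.01 log units; within the scatter), in either direction and within the scatter. Compound 4 is therefore estimated at 30000 nM, in the range 8000 nM to 120000 nM.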

Compound 4, half-maximal inhibitory concentration: 7400 nM
The estimate for compound 4 lay 4.1-fold (0.61 log units) above the measured number; measured number below the stated range.
By their numbers in this assay, from the lowest: compound 2; then compound 4; then compound 3. At a limit, above all of these: compound 1.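

In this assay, among these compounds, phenyl in place of benzyl on a saturated chain carbon bound to an aromatic carbon gives a 4.2-fold lower number from compound 3 to compound 4 (0.62 log units; beyond the scatter), the first direct reading of this chain change. Hydrogen in place of (1-bromoethenyl)carbonyl on a nitrogen on an aromatic ring gives a 2.5-fold higher number from compound 2 to compound 4 (0.39 log units; beyond the scatter), so the free amine retains much of the inhibition seen with the acylated form. Benzyl in place of thiophen-2-yl on an aromatic carbon gives an at least 33-fold lower number from compound 1 to compound 4 (1.52 log units; beyond the scatter), a step read from a limit and not from a number: the limit of > 250000 nM in this assay, at which 1 of the 4 values shown sits.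

The compounds shown leave open whether a longer chain, or an amine on the chain, would shift the number further. They also leave open whether the (1-bromoethenyl)carbonyl group would give a similar step alongside a thiophen-2-yl group.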